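The compounds below may be only part of what the source reports. "The series", "measured", "known", "first", "only" and "open" are said of these compounds alone.

Compound 1 `C=Cc1cccc(C(=O)N2CCCC(C(=O)Nc3ccc(Cl)cc3)C2)c1`: 0%
Compound 2 `Cc1nc(-c2cccc(NC(=O)C3CCCN(C(=O)c4cc(C(F)(F)F)cc(C(F)(F)F)c4)C3)c2)cs1`: 1%

In an ADME assay on PC-3 cells (Homo sapiens) for cytotoxicity, read by WST assay, tested at 100 uM (a lower number here means less inhibition, a higher number more inhibition at the concentration tested (going by the name of the read-out)), compound 1 gives 0% and compound 2 gives 1%. Compound 2 has the higher of the two numbers, but the gap to compound 1 lies within the usual scatter of this kind of measurement, so the two compounds cannot be told apart on these values; both sit at the bottom of the scale. Compound 3 `O=C(Nc1cccc(-c2cnco2)c1)C1CCCN(C(=O)c2cc(C(F)(F)F)cc(C(F)(F)F)c2)C1` has not been measured in this assay. It differs from compound 2 in one place: 1,3-oxazol-5-yl in place of 2-methyl-1,3-thiazol-4-yl on an aromatic carbon. Among the measured compounds shown here, no measured pair shows this same change, so nothing is known about its effect. With both measured compounds showing no inhibition worth the name, the step from compound 2 to compound 3 is expected to be none beyond the scatter, a number 1 percentage points higher from compound 2 to compound 3 (within the scatter). Compound 3 is therefore estimated at 2%, with a range from -8% to 14%.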

Compound 3, a percentage reported as inhibition, at one concentration (the size of the read-out at that concentration, not a potency): 9%
For compound 3 the middle estimate is 7 percentage points below the measured one; the range from low to high includes it.
By their numbers in this assay, from the lowest: compounds 1, 2 and 3 (each within the scatter of the next).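

Among the compounds shown here, replacing 2-methyl-1,3-thiazol-4-yl with 1,3-oxazol-5-yl on an aromatic carbon, meta to a large group, gives a number 8 percentage points higher from compound 2 to compound 3 (within the scatter) in this assay and so provides the first reading of this change at this position. The step does not separate the two groups: each is a five-membered aromatic ring with 2 hetero atoms, and on these values compound 2 and compound 3 cannot be told apart. No measurement available here accounts for the size of this step.

As far as these compounds go, it remains open whether an amine or a carboxylic acid at this position, in place of the five-membered aromatic ring, would move the number beyond the scatter. From the compounds shown here alone, it is also open whether the same exchange would read the same way with a group other than the two trifluoromethyl groups on the benzoyl part of the core.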